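A few compounds are considered here, and "the series" means these few. Any claim that something is new, unique, unknown or untested is made for them only; others in the source may bear on it.

Measured so far:
compound 1, `CN(C)CCCCOc1ccc2oc(-c3ccccc3)cc(=O)c2c1`: 720 nM
compound 2, `O=c1cc(-c2ccccc2)oc2cc(OCCCCCCN3CCC(O)CC3)ccc12`: 45 nM

In an assay on isolated protein (Cavia porcellus) with Sigma non-opioid intracellular receptor 1 (Homo sapiens) as the target, read by radioligand binding (on this read-out higher numbers stand for weaker inhibition and lower numbers for stronger inhibition), compound 2 has the lowest of the two numbers: compound 1 gives 720 nM, while compound 2 gives 45 nM, a gap well beyond the scatter. Compound 3 `O=c1cc(-c2ccccc2)oc2cc(OCCCCCCCN3CCC(O)CC3)ccc12` differs from compound 2 by (4-hydroxypiperidin-1-yl)methyl in place of 4-hydroxypiperidin-1-yl on a saturated chain carbon, six bonds along the chain from an oxygen on an aromatic ring. Among the compounds with values here, no measured pair shows what one added chain carbon does on this assay. The step is expected to be small, a 1.3-fold lower number from compound 2 to compound 3 (0.11 log units; within the scatter), and not beyond the scatter. For compound 3 the estimate on this assay is 35 nM, with a range from 12 nM to 120 nM.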

Compound 3, half-maximal inhibitory concentration: 16 nM
The estimate for compound 3 lay 2.2-fold (0.34 log units) above the measured number; the range from low to high includes it.
By their numbers in this assay, from the lowest: compound 3; then compound 2; then compound 1.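

In this assay the change to (4-hydroxypiperidin-1-yl)methyl gives a 2.8-fold lower number from compound 2 to compound 3 (0.45 log units; beyond the scatter) and adds one chain carbon, a modest step. Within the data shown here, it is the first measured pair in which only the chain length changes, so it shows that this position can respond to one added carbon while the shared core and the hydroxypiperidine ring stay the same. No evidence at hand accounts for this step.

A longer chain could extend the step, stop it or reverse it. Going by these compounds, how a morpholine ring would compare with 4-hydroxypiperidin-1-yl on this chain also stays open.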